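The compounds below may be only part of what the source reports. "The series", "measured", "known", "first", "only" and "open" are said of these compounds alone.

Of the compounds shown here, two have been measured so far in a physicochemical assay for pharmacokinetics, read by HPLC, in phosphate buffer, at pH 7.4 (on this read-out lower numbers stand for a shorter-lived compound and higher numbers for a longer-lived compound), and they share much of their shape. Compound 1 `CCCC(CCC)C(=O)N(C)/N=N/c1ccc(C(=O)OC)cc1` gives 31.4 h in this test. Compound 2 `CCCC(=O)N(C)/N=N/c1ccc(C#N)cc1` reads > 40 h and that reading is a limit of the assay and not a number. Compound 2 therefore stands at the limit of > 40 h in this assay, at which 1 of the 2 values shown sits, and has no exact figure.

Compound 3 `CCC(CC)C(=O)N(C)/N=N/c1ccc(C#N)cc1` comes from compound 2 by a single change, which is ethyl in place of hydrogen on a saturated chain carbon bound to a carbonyl carbon and a saturated chain carbon and which, seen one bond further out, turns propyl into pentan-3-yl. Going by the values given here, no measured pair differs in just one place, so this change has no direct precedent. The nearest guide is compound 1, which also carries a branch on the saturated chain carbon bound to its carbonyl carbon and gives 31.4 h despite differing elsewhere too.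

The expected change is an at least 1.1-fold lower number from compound 2 to compound 3 (0.05 log units; that floor lies within the scatter) and is estimated as a small shortening, perhaps none beyond the usual scatter. Compound 3 is estimated at 35 h with an expected range from 18 h to 70 h when measured.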

Compound 3, half-life: > 40 h
Compound 3: no number, only a limit; the forecaster's own chance of this, stated with the estimate: 40%; at least 1.1-fold (0.05 log units) between middle value and limit.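

No step can be read from compound 2 to compound 3 because each gives a limit of the assay and not a number: the limit of > 40 h in this assay, at which 2 of the 3 values shown sit.

The compounds shown leave open how long either compound actually lasts, and so whether ethyl in place of hydrogen, which turns propyl into pentan-3-yl, changes the half-life at all.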